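Swapping the phenyl phosphate ester for a charged piperidinium

This account rests on a few compounds, and the source may have more. Where it says the series, first, only, none or still open, it means among the compounds named here.

Within the data shown here, compound 1, `O=C(O[C@H]1C[C@H](n2cc(F)c(=O)[nH]c2=O)O[C@@H]1COP(=O)(O)Oc1ccccc1)c1ccccc1`, holds the only numeric value in this set; in a physicochemical assay for metabolic stability, read by HPLC, tested at 2 mM (a lower number here means that the compound disappears faster, a higher number that the compound lasts longer), compound 1 gives 6.6 h. Compound 2, `CCCCCCCCCc1ccc(OP(=O)(O)OC[C@H]2O[C@@H](n3cc(F)c(=O)[nH]c3=O)C[C@@H]2OC(=O)c2ccccc2)cc1`, differs from it by nonyl in place of hydrogen on an aromatic carbon. In this assay compound 2 gives > 120 h, which is a limit of the assay and not a number. Among the measured compounds shown here, the step is an at least 18-fold higher number from compound 1 to compound 2 (1.25 log units; beyond the scatter), the single measured step, and it rests on (the limit of > 120 h in this assay, at which 1 of the 2 values shown sits). Compound 3, `C[N+]1(C)CCC(OP(=O)([O-])OC[C@H]2O[C@@H](n3cc(F)c(=O)[nH]c3=O)C[C@@H]2OC(=O)c2ccccc2)CC1`, carries a change of another kind: a group of 12 heavy atoms (7 carbon, 1 nitrogen, 3 oxygen, 1 phosphorus; one six-membered non-aromatic ring with 1 hetero atom) in place of a group of 10 heavy atoms (6 carbon, 3 oxygen, 1 phosphorus; one six-membered aromatic ring of carbon only), on an oxygen on a saturated carbon. For the measured compounds named here, no measured step shares this change, so the one measured step bears on it only in showing that alteration at the ester end of the phosphate can move the half-life far. A rise is expected, a 4.5-fold higher number from compound 1 to compound 3 (0.66 log units; beyond the scatter). Compound 3 is estimated at 30 h, with a range from 8 h to 120 h.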

Compound 3, half-life: > 120 h
Compound 3: no number, only a limit; the forecaster's own chance of this, stated with the estimate: 25%; at least 4.0-fold (0.60 log units) between middle value and limit.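

Working from the ester end of the phosphate, on an oxygen on a saturated carbon, a group with a six-membered non-aromatic ring with 1 hetero atom in place of the phenyl-bearing group gives an at least 18-fold higher number from compound 1 to compound 3 (1.25 log units; beyond the scatter). The earlier step kept the aromatic ring and added nonyl, whereas this one shows that a long half-life in this assay does not require that ring. For compound 3, > 120 h is a limit of the assay and not a number, so the true size of this step stays unknown because the reading stops at a ceiling: the limit of > 120 h in this assay, at which 2 of the 3 values shown sit.

On these data alone, whether the half-life goes with the nitrogen or with the non-aromatic ring stays open, and a cyclohexyl group on the same oxygen would bear on that. Also open, as far as these compounds go, is where a butyl chain in place of nonyl would fall.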